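A pyrazole in place of a triazole on the side arm

The source may report more compounds than this note shows. Statements on the series, on what has been measured and on what is new or still open speak of the compounds shown alone.

Measured so far:
compound 1, `CCOc1ncc(-c2nc(C(F)(F)F)sc2N2CCN(C(=O)Cn3ccc4cccnc43)[C@H](C)C2)cn1` — 3.8 nM in a functional assay on CHO-K1 cells for antagonist activity at C-X-C chemokine receptor type 3 (Homo sapiens), read by FLIPR, with a stated time of 10 min; a lower number here means a stronger inhibitor, a higher number a weaker inhibitor
compound 2, `CCOc1ncc(-c2nc(C(F)(F)F)sc2N2CCN(C(=O)Cn3nc(C)nc3C)[C@H](C)C2)cn1` — 7 nM in this assay

The two compounds share one core and differ only in the aromatic ring carried on a saturated chain carbon bound to a carbonyl carbon. That single step, a 1.8-fold higher number from compound 1 to compound 2 (0.27 log units; within the scatter), stays within the scatter, so the two numbers cannot be ordered. Compound 2 stands at the higher of the two numbers, with compound 1 as its nearest neighbour, a difference that is within the scatter.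

Compound 3, `CCOc1ncc(-c2nc(C(F)(F)F)sc2N2CCN(C(=O)Cn3ccc(C(F)(F)F)n3)[C@H](C)C2)cn1`, has not yet been measured in this assay. Its change from compound 2 is 3-(trifluoromethyl)-1H-pyrazol-1-yl in place of 3,5-dimethyl-1H-1,2,4-triazol-1-yl on a saturated chain carbon bound to a carbonyl carbon. For the measured compounds named here, the only measured step that bears on this position is a 1.8-fold higher number from compound 1 to compound 2 (0.27 log units; within the scatter), where a quite different aromatic group at the same place left the number within the scatter. On that basis a new aromatic ring here is expected to give no step beyond the scatter, in either direction. The expected step is no change at the digits printed from compound 2 to compound 3 (within the scatter). Compound 3 is therefore expected to give 7 nM, in a range from 2.5 nM to 20 nM.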

Compound 3, half-maximal inhibitory concentration: 3.8 nM
Beside the measured number, compound 3's estimate is 1.8-fold (0.27 log units) above it; low and high end bracket the measured number.
By their numbers in this assay, from the lowest: compounds 1, 3 and 2 (each within the scatter of the next).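

In this assay, the step of a 1.8-fold lower number from compound 2 to compound 3 (0.27 log units; within the scatter) shows that 3-(trifluoromethyl)-1H-pyrazol-1-yl can stand in place of 3,5-dimethyl-1H-1,2,4-triazol-1-yl on a saturated chain carbon bound to a carbonyl carbon with no step beyond the scatter, although the entering group brings in fluorine. The step of no change at the digits printed from compound 1 to compound 3 (within the scatter) adds a second comparison at this place: a group with one five-membered aromatic ring and a group with both a five-membered and a six-membered aromatic ring, each of 9 heavy atoms, cannot be told apart by their numbers. Nothing measured on these compounds speaks to why the numbers stay so close.

As far as these compounds go, all three groups at this place contain an aromatic ring, so it remains open whether an amine, a carboxylic acid or a longer saturated chain there would also stay within the scatter. From the compounds shown here alone, whether a plain 1H-pyrazol-1-yl group, without the trifluoromethyl, would fall with these three numbers is equally open.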